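The compounds below may be only part of what the source reports. "The series", "measured", "known", "first", "only" and "open" are said of these compounds alone.

Of the compounds shown here, two from this set have been measured in an assay on membranes from Cerebral cortex with Alpha-1A adrenergic receptor (Rattus norvegicus) as the target, read by radioligand binding; on this read-out lower numbers stand for stronger inhibition and higher numbers for weaker inhibition. Compound 1, `O=C1C2CCCN2C(=O)N1CCCN1CCN(c2cccc(C(F)(F)F)c2)CC1`, gives 109 nM in this assay. Compound 2, `COc1ccccc1N1CCN(CCCCN2CC3CCCN3C2)CC1`, gives 72.6 nM in this assay. The two numbers lie within the usual scatter of repeated measurements of each other, so compound 2 stands alongside compound 1 rather than apart from it.

Compound 3, `Clc1cccc(N2CCN(CCCCN3CC4CCCN4C3)CC2)c1`, has not yet been measured. It differs from compound 2 in one place: 3-chlorophenyl in place of 2-methoxyphenyl on an amine nitrogen in a ring. Among the measured compounds shown here, no pair of measured compounds shows what such a swap does here, so its effect has to be guessed from the two numbers available, which sit close together despite their different groups on the same ring nitrogen. A step no larger than the scatter, or a modest weakening, is expected, so that the expected step of a 2.1-fold higher number from compound 2 to compound 3 (0.32 log units; beyond the scatter) stays small. For compound 3 the expected value in this assay is 150 nM, with a likely range from 40 nM to 600 nM.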

Compound 3, inhibition constant: 64.9 nM
The estimate for compound 3 lay 2.3-fold (0.36 log units) above the measured number; the measured number falls inside the stated range.
By their numbers in this assay, from the lowest: compounds 3, 2 and 1 (each within the scatter of the next).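

This is the only pair shown that differs in one place, so it gives a direct reading of the group on the amine nitrogen of the six-membered ring with 2 nitrogen: in this assay, 3-chlorophenyl in place of 2-methoxyphenyl gives a 1.1-fold lower number from compound 2 to compound 3 (0.05 log units; within the scatter). On this core, the two groups cannot be told apart in this read-out, even though the leaving group counts one hydrogen-bond acceptor and the entering group none. No outside measurement offers an explanation for this match.

From the compounds shown here alone, two groups say little about the position as a whole, so it remains open whether a plain phenyl or a pyridine ring on that nitrogen would also fit. Going by these compounds, it is also open whether the same swap would read alike with a longer chain or on the core of compound 1.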